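This account rests on a few compounds, and the source may have more. Where it says the series, first, only, none or still open, it means among the compounds named here.

Measured compounds:
Compound 1, `CC(=O)Nc1ccc(S(=O)(=O)NNC(=O)c2cccnc2Nc2ccc(Cl)cc2)cc1`: in a functional assay on MOLT-4 cells (Homo sapiens) for antiproliferative activity (on this read-out lower numbers stand for stronger inhibition of growth and higher numbers for weaker inhibition of growth), compound 1 gives > 100000 nM, which is a limit of the assay.
Compound 2, `O=C(NNS(=O)(=O)c1ccc(F)cc1)c1cccnc1Nc1ccc(Cl)cc1Cl`: in this assay compound 2 gives > 100000 nM, also a limit of the assay.

Compound 1 therefore stands at the limit of > 100000 nM in this assay, at which 2 of the 2 values shown sit, so no number separates it from compound 2. Compound 3, `O=C(NNS(=O)(=O)c1ccc(Cl)cc1Cl)c1cccnc1Nc1ccc(Cl)cc1`, differs from compound 1 by 2,4-dichlorophenyl in place of 4-acetamidophenyl on a sulfonyl sulfur. Within the data shown here, no measured step involves this change; compound 3 is expected to stay at the limit, with no step beyond the scatter in this assay. Compound 3 is thus estimated at 100000 nM (range 20000 nM to 100000 nM), an expected step of a number no higher from compound 1 to compound 3 (the limit leaves the size open).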

Compound 3, concentration for total growth inhibition: 57500 nM
Compound 3: the middle estimate sits 1.7-fold (0.24 log units) above what was measured; low and high end bracket the measured number.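

Among these compounds, on a sulfonyl sulfur, 2,4-dichlorophenyl in place of 4-acetamidophenyl gives the only value in this assay that is a number and not a limit, with compound 3 at 57500 nM. The change gives an at least 1.7-fold lower number from compound 1 to compound 3 (0.24 log units; that floor lies within the scatter). Its true size stays unknown, since the value of compound 1 is a limit: the limit of > 100000 nM in this assay, at which 2 of the 3 values shown sit.

From the compounds shown here alone, what a 4-aminophenyl or a 4-carboxyphenyl group on the sulfonyl sulfur would give remains open. So does how much of the step belongs to each chlorine of the 2,4-dichlorophenyl group.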